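A few compounds are considered here, and "the series" means these few. Any claim that something is new, unique, unknown or untested is made for them only; others in the source may bear on it.

Compound 2 `COc1cccc(C(O)CCn2nc3c(Br)c(Br)c(Br)c(Br)c3n2)c1` stands at the bottom of the two numbers shown in a functional assay on MCF7 cells (Homo sapiens) for antiproliferative activity, read by MTT assay, with a stated time of 48 h, tested at 25 uM (a lower number here means a stronger effect, a higher number a weaker effect of the compound at the concentration tested), where compound 2 gives 96%, while compound 1 `OC(CCn1nc2c(Br)c(Br)c(Br)c(Br)c2n1)c1ccc(F)cc1` gives 97%; the step of a number 1 percentage points lower from compound 1 to compound 2 (within the scatter) lies within the scatter. Compound 3 `OC(CCn1nc2c(Br)c(Br)c(Br)c(Br)c2n1)c1cccc(Cl)c1` differs from compound 2 by chloro in place of methoxy on an aromatic carbon. Going by the values given here, the one step at hand also swapped a substituent on the phenyl ring and barely moved the number, so no step beyond the scatter is expected in this assay here. Compound 3 is therefore expected to give 95%, between 86% and 100%, an expected step of a number 1 percentage points lower from compound 2 to compound 3 (within the scatter).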

Compound 3, a percentage reported as activity, at one concentration (the size of the read-out at that concentration, not a potency): 101%
Compound 3: middle estimate off by 6 percentage points, on the low side, and the stated range ends below it.
By their numbers in this assay, from the lowest: compounds 2, 1 and 3 (each within the scatter of the next).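

In this assay, chloro in place of methoxy on this aromatic carbon gives a number 5 percentage points higher from compound 2 to compound 3 (within the scatter) and 3-chlorophenyl in place of 4-fluorophenyl gives a number 4 percentage points higher from compound 1 to compound 3 (within the scatter), so the third substituent on the phenyl ring also leaves all three compounds within the scatter of one another. Chloro, with one heavy atom against the two of methoxy, separates no compound from the rest. Nothing at hand explains this flat result. Still open, as far as these compounds go, is whether an amine or a carboxylic acid on the phenyl ring, or a longer chain to the core, would bring the number down at this concentration.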